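This account rests on a few compounds, and the source may have more. Where it says the series, first, only, none or still open, it means among the compounds named here.

Three compounds share one core and were tested in a functional assay on the whole organism (aorta) with Rattus norvegicus as the target; a higher number here means a larger maximal response, a lower number a smaller maximal response. Compound 1, `C/N=C(/S)C1=CC(CF)(CF)Oc2ccc([N+](=O)[O-])cc21`, gives 74.5%. Compound 2, `CNC(=O)C1=CC(C)(CF)Oc2ccc([N+](=O)[O-])cc21`, gives 66%. Compound 3, `CNC(=O)C1=CC(CF)(CF)Oc2ccc([N+](=O)[O-])cc21`, gives 70.7%. Compound 3 stands close to both neighbours: the step of a number 3.8 percentage points lower from compound 1 to compound 3 (within the scatter) and the step of a number 4.7 percentage points higher from compound 2 to compound 3 (within the scatter) are each within the scatter, so none of the three can be set apart from the others in this assay.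

Compound 4, `N#CCC/N=C(\S)C1=CC(CF)(CF)Oc2ccc([N+](=O)[O-])cc21`, has not yet been measured. The change from compound 3 to compound 4 is a group of 7 heavy atoms (4 carbon, 2 nitrogen, 1 sulfur; no ring) in place of a group of 4 heavy atoms (2 carbon, 1 nitrogen, 1 oxygen; no ring), on a double-bonded ring carbon. Within the data shown here, of the measured steps, only the exchange on the double-bonded ring carbon in a number 3.8 percentage points lower from compound 1 to compound 3 (within the scatter) bears on it, and that step was within the scatter; the lengthening of the chain on the nitrogen has no measured counterpart here. The step of a number 3.3 percentage points higher from compound 3 to compound 4 (within the scatter) is therefore expected to stay within the scatter, if anything slightly upward. Compound 4 is expected to give about 74%, with a range from 62% to 86%.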

Compound 4, intrinsic activity: the largest response reached, in percent of the reference agonist's: 72.5%
For compound 4 the middle estimate is 1.5 percentage points above the measured one, and the stated range covers the measured number.
By their numbers in this assay, from the lowest: compounds 2, 3, 4 and 1 (each within the scatter of the next).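

In this assay, the double-bonded ring carbon accepts the group of 7 heavy atoms without a resolved change in maximal response. Set against the methylcarbamoyl group, the exchange gives a number 1.8 percentage points higher from compound 3 to compound 4 (within the scatter) and so adds the longer chain to the sulfur-for-oxygen exchange already seen at this position. With sulfur kept in place and only the chain on the nitrogen lengthened, the result is a number 2 percentage points lower from compound 1 to compound 4 (within the scatter) and thus this first look at chain length shows no separable effect on the maximal response. Nothing available here gives a reason for this result. Still open is whether an amine, a carboxylic acid or a longer chain on the same carbon would also stay within the scatter of these compounds. A ring-bearing group at this position also remains an open case.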